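From methyl to ethyl: the step to compound 3

A few compounds are considered here, and "the series" means these few. Any claim that something is new, unique, unknown or untested is made for them only; others in the source may bear on it.

Compound 1 `CCn1c(-c2ccccc2)nn(C)c1=S`: 0.58 mg/kg
Compound 2 `Cn1nc(-c2ccc(Cl)cc2)n(C)c1=S`: 1.34 mg/kg

Both compounds were tested in a functional assay on the whole organism with Mus musculus as the target; a higher number here means that more compound is needed for the effect, a lower number that less compound is needed. Compound 2 stands at the higher number of the two, and compound 1 lies lower by a gap beyond the usual scatter. Compound 3 `CCn1c(-c2ccc(Cl)cc2)nn(C)c1=S` has not yet been measured. It derives from compound 2 by methyl in place of hydrogen on a saturated chain carbon bound to an aromatic nitrogen, which turns methyl to ethyl (methyl in place of hydrogen on a saturated chain carbon bound to an aromatic nitrogen). For the measured compounds named here, no two measured compounds differ in one place only, so the data give no direct size for this change. Going by the values given here, the only hint is that compound 1, which also carries ethyl, gives 0.58 mg/kg. A modest fall in the number is therefore expected, possibly no larger than the scatter. The estimated step is a 1.6-fold lower number from compound 2 to compound 3 (0.20 log units; within the scatter). For compound 3 the expected value is 0.85 mg/kg, within an estimated range of 0.35 mg/kg to 2 mg/kg.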

Compound 3, dose for half-maximal effect: > 50 mg/kg
Compound 3: only a limit was reported; the forecaster's own chance of this, stated with the estimate: 3%; middle value at least 58-fold (1.76 log units) from the limit.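

The value of compound 3 in this assay is a limit and not a number: the limit of > 50 mg/kg in this assay, at which 1 of the 3 values shown sits. Both changes turn out to be large: methyl in place of hydrogen on a saturated chain carbon bound to an aromatic nitrogen gives an at least 37-fold higher number from compound 2 to compound 3 (1.57 log units; beyond the scatter), and chloro in place of hydrogen on an aromatic carbon gives an at least 86-fold higher number from compound 1 to compound 3 (1.93 log units; beyond the scatter). Compound 1 carries ethyl without chloro and compound 2 carries chloro without ethyl, and each has a measured number, whereas only compound 3, which carries both, ends at a limit.

On these data alone, the true size of both steps stays open, since each rests on that limit. Also open, as far as these compounds go, is how a longer chain such as propyl at this place, or a fluoro or methoxy group in place of chloro, would behave.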